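A few compounds are considered here, and "the series" means these few. Any claim that something is new, unique, unknown or untested is made for them only; others in the source may bear on it.

Compound 1 `CCOC(=O)N(C)CC#CCN1CCCC1`: in a functional assay on the whole organism for agonist activity, with Mus musculus as the target (on this read-out higher numbers stand for an effect only at larger amounts of compound and lower numbers for an effect already at smaller amounts), compound 1 gives > 100 mg/kg, which is a limit of the assay and not a number.
Compound 2 `CCOC(=O)N(C)CC#CCn1ccnc1`: in this assay compound 2 gives > 100 mg/kg, again a limit rather than a number.
Compound 3 `Cn1ccn(CC#CCN2CCCC2)c1=O`: in this assay compound 3 gives 6.6 mg/kg.

Compound 1 and compound 2 differ in one place: 1H-imidazol-1-yl in place of pyrrolidin-1-yl on a saturated chain carbon bound to a triple-bonded carbon. Both sit at the limit of > 100 mg/kg in this assay, at which 2 of the 3 values shown sit, so the step that the two limits leave unreadable from compound 1 to compound 2 cannot be sized. Compound 3 has a different core; the difference between the two cores is not broken down here. Compound 4 `Cn1ccn(CC#CCn2ccnc2)c1=O` is not yet measured and differs from compound 3 by 1H-imidazol-1-yl in place of pyrrolidin-1-yl on a saturated chain carbon bound to a triple-bonded carbon, the same change as from compound 1 to compound 2. For the measured compounds named here, because the measured pair sits at the limit of > 100 mg/kg in this assay, at which 2 of the 3 values shown sit, that pair gives no size for the step. For compound 4 the step of a 6.1-fold higher number from compound 3 to compound 4 (0.78 log units; beyond the scatter) in this assay is expected, a loss, resting on compound 3 at 6.6 mg/kg as the starting point. Compound 4 is estimated at 40 mg/kg, between 8 mg/kg and 200 mg/kg.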

Compound 4, dose for half-maximal effect: 4.4 mg/kg
Estimate against measurement, compound 4: 9.1-fold (0.96 log units) above, and the stated range ends above it.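

On the core of compound 3, 1H-imidazol-1-yl in place of pyrrolidin-1-yl gives a 1.5-fold lower number from compound 3 to compound 4 (0.18 log units; within the scatter) in this assay, so on this core the two groups cannot be told apart. On the core of compound 1 the same change cannot be read, since compound 1 and compound 2 both sit at a limit of the assay and not at a number: the limit of > 100 mg/kg in this assay, at which 2 of the 4 values shown sit. The change is therefore sized on one core only, and nothing here shows whether that step carries over to the other core.

Still open, as far as these compounds go, is how other groups in the same place, such as a dimethylamino group or a carboxylic acid, would read out on either core. Also open, from the compounds shown here alone, is whether any group lifts the core of compound 1 off the limit.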